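The source may report more compounds than this note shows. Statements on the series, on what has been measured and on what is new or still open speak of the compounds shown alone.

Compound 1 `COC(=O)c1sc2cc(C#Cc3cccnc3)cnc2c1N` gives > 150000 nM in this assay, a limit of the assay. Compound 2 `COC(=O)c1sc2cc(C#Cc3ccccc3N)cnc2c1N` gives 3100 nM.

In a functional assay on A375-C5 cells (Homo sapiens) for inhibition, read by sulforhodamine B assay, with a stated time of 48 h (a lower number here means a stronger inhibitor of growth, a higher number a weaker inhibitor of growth), compound 2 holds the only number shown; for compound 1 the value is a limit (the limit of > 150000 nM in this assay, at which 1 of the 2 values shown sits). Compound 3 `COC(=O)c1sc2cc(C#Cc3ccc(F)cc3)cnc2c1N` differs from compound 2 by 4-fluorophenyl in place of 2-aminophenyl on a triple-bonded carbon. Within the data shown here, the one measured step that bears on this change, an at least 48-fold lower number from compound 1 to compound 2 (1.68 log units; beyond the scatter), shows that exchanging the ring on the triple-bonded carbon can move the number strongly, and here the 2-aminophenyl of compound 2 is removed. Compound 3 is therefore expected to be weaker, estimated at 30000 nM (range 5000 nM to 150000 nM), a step of a 9.7-fold higher number from compound 2 to compound 3 (0.99 log units; beyond the scatter), with a real chance that only a limit is reported.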

Compound 3, concentration for 50% growth inhibition: 48400 nM
For compound 3 the middle estimate is 1.6-fold (0.21 log units) below the measured one; the measured number falls inside the stated range.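

In this assay, the second exchange on the triple-bonded carbon confirms that compound 2 is the strongest of the three: a 16-fold higher number from compound 2 to compound 3 (1.19 log units; beyond the scatter). 4-Fluorophenyl does not recover what 2-aminophenyl gives, yet the reading still shows a separation among the weaker rings, an at least 3.0-fold lower number from compound 1 to compound 3 (0.49 log units; beyond the scatter). That separation has only a lower bound, since compound 1 stands at a limit: the limit of > 150000 nM in this assay, at which 1 of the 3 values shown sits.

The step from compound 2 to compound 3 removes the amine and brings in fluorine at once, so the two changes stay unseparated. A plain phenyl, or a hydroxyl in place of the amine, would bear on which part counts.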